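The compounds below may be only part of what the source reports. "The series", "measured", "known", "first", "only" and "open" are said of these compounds alone.

Compound 1, `C/N=C(/S)C1=CC(C)(C)Oc2ccc([N+](=O)[O-])cc21`: 63.5%
Compound 2, `C/N=C(/S)C1=CC(C)(CF)Oc2ccc([N+](=O)[O-])cc21`: 77.1%
Compound 3, `C/N=C(/S)C1=CC(CF)(CF)Oc2ccc([N+](=O)[O-])cc21`: 74.5%

In a functional assay on the whole organism (aorta) with Rattus norvegicus as the target (a lower number here means a smaller maximal response, a higher number a larger maximal response), compound 2 gives 77.1%, the highest of the three numbers, though compound 3 lies within the scatter of it and only the gap to compound 1 is beyond the scatter. The unmeasured compound 4, `C/N=C(/S)C1=CC(C)(C(F)(F)F)Oc2ccc([N+](=O)[O-])cc21`, differs from compound 2 in one place: trifluoromethyl in place of fluoromethyl on a saturated ring carbon. Within the data shown here, two measured steps bear on this change, both of them fluoro in place of hydrogen on a saturated chain carbon bound to a saturated ring carbon. The first, a number 13.6 percentage points higher from compound 1 to compound 2 (beyond the scatter), was a modest rise beyond the scatter. The second, a number 2.6 percentage points lower from compound 2 to compound 3 (within the scatter), stayed within the scatter. Adding fluorine has thus raised the maximal response once and left it unchanged once, and no measured step shows what happens when two further fluorines go onto a chain carbon that already bears one. Compound 4 is therefore expected to stay near compound 2, with a step of a number 0.9 percentage points higher from compound 2 to compound 4 (within the scatter), at most a small move that could go either way. The estimate for compound 4 is 78%, expected between 62% and 92%.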

Compound 4, intrinsic activity: the largest response reached, in percent of the reference agonist's: 62.5%
Beside the measured number, compound 4's estimate is 15.5 percentage points above it; low and high end bracket the measured number.
By their numbers in this assay, from the lowest: compounds 4 and 1 (each within the scatter of the next); then compounds 3 and 2 (each within the scatter of the next).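

In this assay, trifluoromethyl in place of fluoromethyl on the saturated ring carbon next to the ring oxygen gives a number 14.6 percentage points lower from compound 2 to compound 4 (beyond the scatter) and so shows that adding fluorine at this position can also lower the maximal response, which neither earlier step showed. Trifluoromethyl in place of methyl on the same carbon gives a number 1 percentage points lower from compound 1 to compound 4 (within the scatter) and so shows that the rise seen with fluoromethyl is not kept once all three hydrogens of that methyl are replaced: across compound 1, compound 2 and compound 4, the maximal response does not climb steadily with the number of fluorines on this carbon. Nothing available accounts for this reversal.

The compounds shown leave open where difluoromethyl on this carbon would fall, and thus whether the response declines gradually or abruptly after fluoromethyl. They also leave open whether an ethyl or hydroxymethyl group here would keep the higher response of compound 2, and how trifluoromethyl would behave with fluoromethyl rather than methyl on the same ring carbon.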